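The source may hold more compounds than are shown below. What is called first, only, known or untested is meant among the compounds shown, and "the series" means these compounds.

Compound 1 `CCCCc1nc(C)c(CC(=O)N2CCN(C)CC2)c(=O)n1Cc1ccc(-c2ccccc2-c2nnn[nH]2)cc1`: "not determined" (no result reported)
Compound 2 `CCCCc1nc(C)c(CC(=O)N2CC(C)OC(C)C2)c(=O)n1Cc1ccc(-c2ccccc2-c2nnn[nH]2)cc1`: 0.029 mg/kg
Compound 3 `CCCCc1nc(C)c(CCC(=O)N2CCOCC2)c(=O)n1Cc1ccc(-c2ccccc2-c2nnn[nH]2)cc1`: 0.143 mg/kg

In an in vivo functional assay on the whole organism for inhibition, with Rattus norvegicus as the target (on this read-out lower numbers stand for an effect already at smaller amounts and higher numbers for an effect only at larger amounts of compound), compound 3 gives 0.143 mg/kg, the higher of the two numbers available, and compound 1 offers no number to compare. Compound 4 `CCCCc1nc(C)c(CCC(=O)N2CC(C)OC(C)C2)c(=O)n1Cc1ccc(-c2ccccc2-c2nnn[nH]2)cc1` differs from compound 3 by 2,6-dimethylmorpholin-4-yl in place of morpholin-4-yl on a carbonyl carbon, with 2,6-dimethylmorpholin-4-yl in place of morpholin-4-yl on a carbonyl carbon. Going by the values given here, only one measured step bears on this, a 4.9-fold higher number from compound 2 to compound 3 (0.69 log units; beyond the scatter). It contains the same ring exchange in reverse, but mixed with a change of chain, and the data do not separate the two. Part of that step is therefore expected to return, giving an expected step of a 2.2-fold lower number from compound 3 to compound 4 (0.34 log units; beyond the scatter) in this assay. For compound 4 the estimated value is 0.065 mg/kg, with an expected range from 0.025 mg/kg to 0.17 mg/kg.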

Compound 4, dose for half-maximal effect: 0.228 mg/kg
The estimate for compound 4 lay 3.5-fold (0.55 log units) below the measured number, and the stated range ends below it.
By their numbers in this assay, from the lowest: compound 2; then compounds 3 and 4 (each within the scatter of the next).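

In this assay, exchanging morpholin-4-yl for 2,6-dimethylmorpholin-4-yl on a carbonyl carbon whose other neighbour is a saturated chain carbon gives a difference within the scatter (a 1.6-fold higher number from compound 3 to compound 4 (0.20 log units; within the scatter)). With 2,6-dimethylmorpholin-4-yl held constant, the change from (2,6-dimethylmorpholin-4-yl)carbonyl to ((2,6-dimethylmorpholin-4-yl)carbonyl)methyl gives a step beyond the scatter (a 7.9-fold higher number from compound 2 to compound 4 (0.90 log units; beyond the scatter)), so the chain change can now be read apart from the ring exchange. Nothing available explains either step. The compounds shown leave open how a piperidine ring or a dimethylamino group on the carbonyl carbon would read on either chain. Going by these compounds, a longer chain also remains open.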